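This account rests on a few compounds, and the source may have more. Where it says the series, first, only, none or still open, it means among the compounds named here.

Compound 2 `C=CCC/C(C)=N\Nc1nc(-c2cccc([N+](=O)[O-])c2)cs1` gives 1040000 nM in a functional assay, with a stated time of 16 h; on this read-out higher numbers stand for weaker inhibition and lower numbers for stronger inhibition. Among the compounds with values here, the only other measured number belongs to compound 1 `CC(C)=NNc1nc(-c2cccc([N+](=O)[O-])c2)cs1`, which gives 1070000 nM in this assay, and the two numbers sit within the scatter of each other. Compound 3 `CCCCCC/C(C)=N\Nc1nc(-c2cccc([N+](=O)[O-])c2)cs1` differs from compound 2 by butyl in place of vinyl on a saturated chain carbon, two bonds along the chain from a carbon with a double bond to nitrogen. Within the data shown here, the one step that bears on this, also a lengthening of the same chain, was a 1.0-fold lower number from compound 1 to compound 2 (0.01 log units; within the scatter). A further lengthening is therefore expected to bring no step beyond the scatter in this assay. Compound 3 is estimated at 1000000 nM, between 450000 nM and 2200000 nM, which means an expected step of a 1.0-fold lower number from compound 2 to compound 3 (0.02 log units; within the scatter).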

Compound 3, half-maximal inhibitory concentration: 1110000 nM
Compound 3: middle estimate off by 1.1-fold (0.05 log units), on the low side; the range from low to high includes it.
By their numbers in this assay, from the lowest: compounds 2, 1 and 3 (each within the scatter of the next).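

In this assay, butyl in place of vinyl gives a 1.1-fold higher number from compound 2 to compound 3 (0.03 log units; within the scatter) and stays within the scatter, so at this saturated chain carbon, the chain without a double bond reads the same as the one with it. Pentyl in place of hydrogen gives a 1.0-fold higher number from compound 1 to compound 3 (0.02 log units; within the scatter) and also stays within the scatter, so this longer chain leaves the number unmoved as well. Nothing measured here offers an explanation for this. Still open, as far as these compounds go, is whether a longer chain, a phenyl ring, an amine or a carboxylic acid on this chain would bring a step beyond the scatter.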